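The compounds below may be only part of what the source reports. "The series", "measured", "known", "first", "only" and "open" are said of these compounds alone.

Measured so far in a functional assay on HCT-116 cells (Homo sapiens) for antiproliferative activity, read by MTT assay, with a stated time of 72 h; a higher number here means a weaker inhibitor, a lower number a stronger inhibitor:

- Compound 1 `CN(C(=O)CCc1ccccc1)c1ccc2[nH]c(-c3n[nH]c4ccccc34)cc2n1`: 11200 nM
- Compound 2 `CN(C(=O)c1ccc([N+](=O)[O-])cc1)c1ccc2[nH]c(-c3n[nH]c4ccccc34)cc2n1`: 19900 nM

Among the compounds with values here, with only two numbers available, compound 2 at 19900 nM cannot be set apart from compound 1 at 11200 nM, since the two lie within the scatter of each other. The next compound to be tested is compound 3 `CN(C(=O)Nc1ccccc1)c1ccc2[nH]c(-c3n[nH]c4ccccc34)cc2n1`, which keeps the shared core and changes one group: anilino in place of 4-nitrophenyl on a carbonyl carbon.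

Within the data shown here, no measured compound yet carries anilino at this place, so the data do not show directly what this group does. Among the measured compounds shown here, the one step that bears on the question is a 1.8-fold higher number from compound 1 to compound 2 (0.25 log units; within the scatter), where 4-nitrophenyl stands in place of phenethyl on a carbonyl carbon. That exchange of groups at the same place stayed within the scatter, so no change beyond the scatter is expected in this assay this time either.

The expected move is a 1.3-fold lower number from compound 2 to compound 3 (0.12 log units; within the scatter), which is no real shift. For compound 3 the estimated value is 15000 nM, with an expected range from 6000 nM to 40000 nM.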

Compound 3, half-maximal inhibitory concentration: 1.3 nM
Compound 3: the middle estimate sits 12000-fold (4.06 log units) above what was measured, and the stated range ends above it.
By their numbers in this assay, from the lowest: compound 3; then compounds 1 and 2 (each within the scatter of the next).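

In this assay, the group on the carbonyl carbon proves able to change the result enormously, a range that the first two compounds gave no hint of: anilino in place of 4-nitrophenyl produces a very large step (a 15000-fold lower number from compound 2 to compound 3 (4.18 log units; beyond the scatter)), and anilino in place of phenethyl produces one of similar scale (an 8600-fold lower number from compound 1 to compound 3 (3.94 log units; beyond the scatter)). Compound 1 and compound 2 lie within the scatter of each other, so among the three groups shown at this place, only anilino stands apart, while the shared core stays the same throughout. Nothing measured here explains why this exchange has such a large effect.

The compounds shown leave open which part of anilino matters, since neither benzylamino nor methylamino on the same carbonyl carbon is among them. They also leave open whether a number this low would survive a chlorine or a methoxy group on the anilino ring, which is the simplest way to learn how much room this group allows.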